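Lengthening the Straight Chain in a Cytotoxicity Series

The source may hold more compounds than are shown below. What is called first, only, known or untested is meant among the compounds shown, and "the series" means these compounds.

In an ADME assay on Vero cells (Chlorocebus sabaeus) for cytotoxicity, read by MTT assay (a higher number here means a weaker inhibitor, a lower number a stronger inhibitor), compound 1 (`CCC(C)CC(=O)OCC(C)(C)CC1=C(O)C(=O)c2ccccc2C1=O`), with a sec-butyl group, gives 2300 nM. With butyl at that place, compound 2 (`CCCCCC(=O)OCC(C)(C)CC1=C(O)C(=O)c2ccccc2C1=O`) gives 169000 nM, and with heptyl, compound 3 (`CCCCCCCCC(=O)OCC(C)(C)CC1=C(O)C(=O)c2ccccc2C1=O`) gives 150000 nM. Compound 3 therefore stands level with compound 2, within the scatter, and far higher than compound 1.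

The change leading to compound 4 (`CCCCCCCCCCC(=O)OCC(C)(C)CC1=C(O)C(=O)c2ccccc2C1=O`) is ethyl in place of hydrogen on a saturated chain carbon, eight bonds along the chain from a carbonyl carbon. Going by the values given here, the closest precedent is a 1.1-fold lower number from compound 2 to compound 3 (0.05 log units; within the scatter), a lengthening of the same straight chain nearer the carbonyl carbon, and it stays within the scatter. The large steps, a 73-fold higher number from compound 1 to compound 2 (1.87 log units; beyond the scatter) and a 65-fold higher number from compound 1 to compound 3 (1.81 log units; beyond the scatter), both replace the sec-butyl group, so they bear little on this change. That leaves a single precedent, and it points to no step beyond the scatter. The expected step is a 1.1-fold lower number from compound 3 to compound 4 (0.03 log units; within the scatter). Compound 4 is expected at about 140000 nM, with an estimated range of 60000 nM to 300000 nM.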

Compound 4, half-maximal inhibitory concentration: > 233000 nM
Compound 4 ended at the assay's limit; the forecaster's own chance of this, stated with the estimate: 15%; middle value at least 1.6-fold (0.22 log units) away from the limit.
By their numbers in this assay, from the lowest: compound 1; then compounds 3 and 2 (each within the scatter of the next). At a limit, above all of these: compound 4.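

In this assay compound 4 sits at a limit of the assay, not at a number: the limit of > 233000 nM in this assay, at which 1 of the 4 values shown sits. The ethyl in place of hydrogen, eight bonds along the chain from a carbonyl carbon, therefore gives an at least 1.5-fold higher number from compound 3 to compound 4 (0.19 log units; that floor lies within the scatter), and pentyl in place of hydrogen gives an at least 1.3-fold higher number from compound 2 to compound 4 (0.13 log units; that floor lies within the scatter); both floors lie within the scatter, so the longest straight chain is not shown to differ from the two shorter ones. Nonyl in place of sec-butyl gives an at least 100-fold higher number from compound 1 to compound 4 (2.00 log units; beyond the scatter), so all three straight chains, in compounds 2, 3 and 4, now stand far from the sec-butyl compound.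

Going by these compounds, how far compound 4 lies past its limit remains open. Also open, on these data alone, is whether another branched chain, or an amine in place of the chain, would give a number as low as that of compound 1.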